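A few compounds are considered here, and "the series" means these few. Any claim that something is new, unique, unknown or untested is made for them only; others in the source may bear on it.

In a functional assay on the whole organism (strain Wistar) with Rattus norvegicus as the target, read by paw edema (a lower number here means that less compound is needed, a higher number that more compound is needed for the effect), compound 1 (`CCC(=O)OCc1cc(-n2nc(C(F)(F)F)cc2-c2ccc(SC)cc2)ccc1S(N)(=O)=O`) gives 60 mg/kg, compound 2 (`CCC(=O)OCc1cc(-n2nc(C(F)(F)F)cc2-c2ccc(OC)c(C)c2)ccc1S(N)(=O)=O`) gives 10.9 mg/kg, and compound 3 (`NS(=O)(=O)c1ccc(-n2nc(C(F)(F)F)cc2-c2ccc3c(c2)CCO3)cc1CO`) gives 22.3 mg/kg, the middle of the three numbers. The next structure, compound 4 (`CCC(=O)OCc1cc(-n2nc(C(F)(F)F)cc2-c2ccc3c(c2)CCO3)ccc1S(N)(=O)=O`), differs from compound 3 by propanoyl in place of hydrogen on an oxygen on a saturated carbon, which turns hydroxymethyl into (propanoyloxy)methyl. Among the compounds with values here, no measured step covers this change. The only one available, a 5.5-fold lower number from compound 1 to compound 2 (0.74 log units; beyond the scatter), involves a different substituent, and both of its compounds already carry (propanoyloxy)methyl. It shows only that, with this group present, the number can still shift by a modest amount. The value of compound 3 lies between those of compound 1 and compound 2, so the data give no direction for adding propanoyl, and no step beyond the scatter is expected. The expected change is a 1.1-fold lower number from compound 3 to compound 4 (0.05 log units; within the scatter), which would stay within the scatter. For compound 4 the estimate is 20 mg/kg, with an expected range from 8 mg/kg to 50 mg/kg.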

Compound 4, dose for half-maximal effect: 8.5 mg/kg
Compound 4: the middle estimate sits 2.4-fold (0.37 log units) above what was measured, and the stated range covers the measured number.
By their numbers in this assay, from the lowest: compounds 4 and 2 (each within the scatter of the next); then compound 3; then compound 1.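

In this assay, within the data shown here, propanoyl in place of hydrogen on the oxygen of the hydroxymethyl group gives a 2.6-fold lower number from compound 3 to compound 4 (0.42 log units; beyond the scatter), so this change, which no earlier pair could read directly, moves the number beyond the scatter. With (propanoyloxy)methyl held constant, exchanging the group on the aromatic carbon gives a 1.3-fold lower number from compound 2 to compound 4 (0.11 log units; within the scatter), which is within the scatter, and a 7.1-fold lower number from compound 1 to compound 4 (0.85 log units; beyond the scatter), which is beyond it, so the outcome at that place depends on which groups are exchanged. Nothing given here accounts for either effect.

The compounds shown leave open whether an acetyl group or a butanoyl chain on this oxygen would give a similar step. They also leave open whether an amine at this place, or propanoyl paired with other aromatic groups, would do the same.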